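The source may hold more compounds than are shown below. What is called first, only, known or untested is meant among the compounds shown, and "the series" means these compounds.

Compound 1 `Cc1cc(C)c2c(O)cc(-c3ccc(Cl)cc3)nc2n1`: 16200 nM
Compound 2 `COc1ccc(-c2cc(O)c3cccnc3n2)cc1`: 64600 nM
Compound 3 `COc1ccc(-c2cc(O)c3c(C)cc(C)nc3n2)cc1`: 42700 nM

All three compounds were tested in a functional assay on SF-295 cells (Homo sapiens); a lower number here means a stronger inhibitor of growth, a higher number a weaker inhibitor of growth. For the measured compounds named here, compound 3 lies within the scatter of compound 2, and the one measured single-place step is a 2.6-fold higher number from compound 1 to compound 3 (0.42 log units; beyond the scatter).

The next compound is compound 4 `COc1ccc(-c2cc(O)c3ccc(C)nc3n2)cc1`. It differs from compound 3 by hydrogen in place of methyl on an aromatic carbon, opposite the ring nitrogen: hydrogen in place of methyl on an aromatic carbon.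

Going by the values given here, no measured step makes this exact change. The step involving compound 1 and compound 3 is a different swap, methoxy in place of chloro, so it offers little guidance here. Compound 2 is more telling. It lacks this methyl and the other methyl on the core, and compound 2 gives 64600 nM, within the scatter of compound 3 at 42700 nM. Losing only one methyl is therefore expected to cause no step beyond the scatter, with any drift towards a higher number. The expected change is a 1.2-fold higher number from compound 3 to compound 4 (0.07 log units; within the scatter).

Compound 4 is estimated at 50000 nM, with an expected range from 26000 nM to 90000 nM.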

Compound 4, concentration for 50% growth inhibition: 89100 nM
Compound 4: middle estimate off by 1.8-fold (0.25 log units), on the low side, and the stated range covers the measured number.
By their numbers in this assay, from the lowest: compound 1; then compounds 3, 2 and 4 (each within the scatter of the next, the first and the last beyond it).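

In this assay, taking away the methyl opposite the ring nitrogen gives a 2.1-fold higher number from compound 3 to compound 4 (0.32 log units; beyond the scatter) and so shows that this one position can move the result beyond the scatter, which the closeness of compound 2 and compound 3 had not revealed. For the compounds shown here, the core's other methyl behaves differently in the one pair that isolates it, with a 1.4-fold higher number from compound 2 to compound 4 (0.14 log units; within the scatter) staying within the scatter. Nothing measured here gives a reason for this difference between the two methyl positions.

On these data alone, each step rests on one pair of compounds, so it remains open whether the methyl opposite the ring nitrogen has the same effect when the methoxy is replaced by the chloro of compound 1. As far as these compounds go, how a longer chain such as ethyl, or an amine, would compare with methyl at this position also remains open.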